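The source may report more compounds than this note shows. Statements on the series, on what has been measured and on what is new or still open speak of the compounds shown alone.

Measured compounds:
- compound 1 `COC(=O)C1=C(C)NC(=O)NC1c1ccccc1`: an assay for inhibition of beta-glucuronidase (Bos taurus), read by spectrophotometry, with a stated time of 30 min; on this read-out lower numbers stand for stronger inhibition and higher numbers for weaker inhibition "not active" (no number reported)
- compound 2 `COC(=O)C1=C(C)NC(=O)NC1CC(C)C`: this assay 55200 nM

For the measured compounds named here, compound 2 gives the only number in this assay; the other entry, compound 1, is reported as not active, with no number. Going by the values given here, what the two entries show is that compound 2 has a measured value where compound 1 has none; no step between them is computed here.

Compound 3 `COC(=O)C1=C(C)NC(=O)NC1c1ccc(C)o1` differs from compound 2 by 5-methylfuran-2-yl in place of isobutyl on a saturated ring carbon. Among the compounds with values here, no step between measured compounds is available for this change. Compound 2 already sits at a weak value, and the single comparator, compound 1, returned no number at all, so the expectation for compound 3 is a step toward weaker inhibition, a 2.2-fold higher number from compound 2 to compound 3 (0.34 log units; beyond the scatter), with a real chance that only a limit is reported. Compound 3 is estimated at 120000 nM, between 40000 nM and 400000 nM.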

Compound 3, half-maximal inhibitory concentration: 44200 nM
For compound 3 the middle estimate is 2.7-fold (0.43 log units) above the measured one; measured number inside the range.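

In this assay the exchange of isobutyl for 5-methylfuran-2-yl on a saturated ring carbon comes out as a 1.2-fold lower number from compound 2 to compound 3 (0.10 log units; within the scatter), so at this position an open branched chain and a five-membered aromatic ring with 1 hetero atom are not told apart by this read-out. Compound 3 gives a number where compound 1 gives "not active" (no number reported), so an aromatic ring at this position does not by itself go with the lack of a number. No measurement at hand gives a reason for either result.

As far as these compounds go, it remains open which feature of the 5-methylfuran-2-yl group separates compound 3 from compound 1, the methyl or the ring oxygen. Also open, from the compounds shown here alone, is what an amine, a carboxylic acid or a longer chain at this position would give.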